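This account rests on a few compounds, and the source may have more. Where it says the series, first, only, none or still open, it means among the compounds named here.

Compound 2 `O=C(O)c1cn(C2CC2)c2cc(N3CCN(Cn4nc(-c5ccc(O)cc5)n(-c5ccc(F)cc5)c4=S)CC3)c(F)cc2c1=O` gives 106000 nM in an ADME assay on HEK293 cells (Homo sapiens) for cytotoxicity, read by MTT assay, with a stated time of 72 h (a higher number here means that more compound is needed for the effect, a lower number that less compound is needed), and this number is within the scatter of compound 1 `COc1ccc(-n2c(-c3cccc(O)c3)nn(CN3CCN(c4cc5c(cc4F)c(=O)c(C(=O)O)cn5C4CC4)CC3)c2=S)cc1`, which gives 114000 nM in this assay. Compound 3 `COc1ccc(-n2c(-c3ccc(O)cc3)nn(CN3CCN(c4cc5c(cc4F)c(=O)c(C(=O)O)cn5C4CC4)CC3)c2=S)cc1` differs from compound 2 by methoxy in place of fluoro on an aromatic carbon. No step beyond the scatter is expected, because compound 1 with its methoxy group gives 114000 nM, close to compound 2. For compound 3 the estimated value in this assay is 110000 nM, with a range from 60000 nM to 200000 nM, meaning an expected step of a 1.0-fold higher number from compound 2 to compound 3 (0.02 log units; within the scatter) that should stay within the scatter.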

Compound 3, half-maximal effective concentration: 105000 nM
Compound 3: middle estimate off by 1.0-fold (0.02 log units), on the high side, within the range that was stated.
By their numbers in this assay, from the lowest: compounds 3, 2 and 1 (each within the scatter of the next).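

Compounds 1 and 2 differ in two places, so only these new pairs separate the changes. In this assay, methoxy in place of fluoro on the aromatic carbon para to a large group gives a 1.0-fold lower number from compound 2 to compound 3 (0.00 log units; within the scatter), and 4-hydroxyphenyl in place of 3-hydroxyphenyl gives a 1.1-fold lower number from compound 1 to compound 3 (0.04 log units; within the scatter), so neither single change moves the number beyond the scatter. Nothing available offers an explanation for these results.

Still open, as far as these compounds go, is whether an amine, a carboxylic acid or a longer alkoxy chain at this position would leave the number just as unchanged.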